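Stereocentre inversion in a weakly inhibiting series

The source may hold more compounds than are shown below. What is called first, only, known or untested is meant among the compounds shown, and "the series" means these compounds.

Measured compounds in this assay:
compound 1 `C[C@H]1O[C@@H](n2c(Br)nc3cc(Cl)c(Cl)cc32)[C@H](O)[C@@H]1O` gives > 100000 nM in a functional assay on KB cells (Homo sapiens) for inhibition (a higher number here means a weaker inhibitor, a lower number a stronger inhibitor), which is a limit of the assay and not a number.
compound 2 `C[C@H]1O[C@@H](n2c(Cl)nc3cc(Cl)c(Cl)cc32)[C@H](O)[C@@H]1O` gives 75000 nM.

Compound 2 thus holds the only number shown; the other value is a limit, as noted for compound 1 (the limit of > 100000 nM in this assay, at which 1 of the 2 values shown sits). Compound 3 `C[C@@H]1O[C@@H](n2c(Cl)nc3cc(Cl)c(Cl)cc32)[C@H](O)[C@@H]1O` differs from compound 2 only in configuration: the two compounds have the same atoms and bonds and differ only in configuration as drawn: 1 of 4 stereo elements differ; a stereocentre at a saturated ring carbon is drawn R in compound 2 and S in compound 3. Among the measured compounds shown here, no measured step alters a stereocentre; the single step, an at least 1.3-fold lower number from compound 1 to compound 2 (0.12 log units; that floor lies within the scatter), exchanges halogens and falls within the scatter, so it offers little guidance. The expected change is a 1.1-fold higher number from compound 2 to compound 3 (0.03 log units; within the scatter), with wide uncertainty. Compound 3 is estimated at 80000 nM, from 20000 nM to 300000 nM, with a fair chance that only a limit is returned.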

Compound 3, half-maximal inhibitory concentration: 60000 nM
Compound 3: middle estimate off by 1.3-fold (0.12 log units), on the high side, within the range that was stated.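

Inverting the one differing stereocentre, at a saturated ring carbon, gives a 1.3-fold lower number from compound 2 to compound 3 (0.10 log units; within the scatter) in this assay. Among the compounds shown here, this is the first reading of configuration, and at this carbon inversion alone does not separate the two compounds. The comparison is a clean one: the fact that compounds 2 and 3 differ only in the configuration as drawn.

Open, on these data alone, is whether inverting any other stereo element moves the number beyond the scatter. Also open, as far as these compounds go, is whether an amine in place of the halogen exchanged between compound 1 and compound 2 would move the number clear of the assay's limit: the limit of > 100000 nM in this assay, at which 1 of the 3 values shown sits.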